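The compounds below may be only part of what the source reports. "The series", "measured", "known", "first", "only" and "open" are said of these compounds alone.

Among the compounds with values here, compound 3 `N#Cc1ccc(CSc2ncnc3c2ncn3[C@@H]2O[C@H](CO)[C@@H](O)[C@H]2O)cc1` gives 4.57 nM in an assay on isolated protein for inhibition of Equilibrative nucleoside transporter 1 (Homo sapiens) (on this read-out lower numbers stand for stronger inhibition and higher numbers for weaker inhibition), and holds the lowest number of the three measured so far; compound 1 `OC[C@H]1O[C@@H](n2cnc3c(SCc4ccccc4I)ncnc32)[C@H](O)[C@@H]1O` gives 19.5 nM and compound 2 `N#Cc1ccccc1CSc1ncnc2c1ncn2[C@@H]1O[C@H](CO)[C@@H](O)[C@H]1O` gives 38.9 nM. The step to compound 4 `O=[N+]([O-])c1ccccc1CSc1ncnc2c1ncn2[C@@H]1O[C@H](CO)[C@@H](O)[C@H]1O` is 2-nitrophenyl in place of 4-cyanophenyl on a saturated chain carbon bound to a sulfur. Within the data shown here, two measured steps bear on it. The move of the cyano group from the 4-position of the phenyl ring to the 2-position is seen in an 8.5-fold lower number from compound 2 to compound 3 (0.93 log units; beyond the scatter) read backwards, a clear loss. Whether the group at the 2-position is iodo or cyano hardly matters, as a 2.0-fold higher number from compound 1 to compound 2 (0.30 log units; within the scatter) shows, and a 4.3-fold lower number from compound 1 to compound 3 (0.63 log units; beyond the scatter) is consistent with the position of the substituent carrying the effect. Compound 4 carries a different group again at the 2-position, so the expected outcome for compound 4 is a 6.6-fold higher number from compound 3 to compound 4 (0.82 log units; beyond the scatter), a return toward the numbers of compound 1 and compound 2. The estimate for compound 4 in this assay is 30 nM, with a range from 10 nM to 100 nM.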

Compound 4, inhibition constant: 115 nM
For compound 4 the middle estimate is 3.8-fold (0.58 log units) below the measured one; the measured number lies above the stated range.
By their numbers in this assay, from the lowest: compound 3; then compounds 1 and 2 (each within the scatter of the next); then compound 4.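

In this assay the group on the ring now matters in its own right: 2-nitrophenyl gives a higher number than either 2-cyanophenyl (a 3.0-fold higher number from compound 2 to compound 4 (0.47 log units; beyond the scatter)) or 2-iodophenyl (a 5.9-fold higher number from compound 1 to compound 4 (0.77 log units; beyond the scatter)), whereas the earlier swap of iodo for cyano stayed within the scatter. Within the data shown here, the widest step so far is the change from 4-cyanophenyl to 2-nitrophenyl (a 25-fold higher number from compound 3 to compound 4 (1.40 log units; beyond the scatter)), but it alters the group and its ring position together and so cannot be assigned to either alone. No measured evidence accounts for the higher number with nitro.

Nitro appears only as 2-nitrophenyl, so it remains open how much of the loss belongs to the group and how much to its ring position. As far as these compounds go, how an amine or a carboxylic acid on the phenyl ring would read also remains open.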